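Notes on the amide aryl change from compound 3 to compound 4

This account rests on a few compounds, and the source may have more. Where it says the series, first, only, none or still open, it means among the compounds named here.

Compound 1 `CN(C(=O)c1c(O)c2c(C(F)(F)F)cccc2n(C)c1=O)c1ccccc1`, compound 2 `COc1cccc2c1c(O)c(C(=O)N(C)c1ccccc1F)c(=O)n2C` and compound 3 `COc1cccc2c1c(O)c(C(=O)N(C)c1cc(F)ccc1F)c(=O)n2C` have each been run in a functional assay on the whole organism for inhibition, with Mus musculus as the target, at a dose of 1 mg/kg by the oral route; a lower number here means less inhibition, a higher number more inhibition at the dose given (going by the name of the read-out). Compound 1 gives 99%, compound 2 gives 82% and compound 3 gives 90%. On these numbers compound 3 sits within the usual scatter of both others: compound 2 is the nearest to it and compound 1 the furthest, and neither gap is beyond the scatter. Going by the values given here, the only step between measured compounds that differ in one place is a number 8 percentage points higher from compound 2 to compound 3 (within the scatter), fluoro in place of hydrogen on an aromatic carbon.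

Compound 4 `COc1cccc2c1c(O)c(C(=O)N(C)c1ccccc1Cl)c(=O)n2C` has not yet been measured in this assay. Against compound 3 its change is 2-chlorophenyl in place of 2,5-difluorophenyl on an amide-type nitrogen. Part of this change reverses the step from compound 2 to compound 3, which itself stayed within the scatter; no measured pair covers the rest of the change. The expected step is therefore a number 5 percentage points lower from compound 3 to compound 4 (within the scatter), none beyond the scatter. Compound 4 is estimated at 85%, with a range from 68% to 98%.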

Compound 4, a percentage reported as inhibition, in the whole organism at one dose (the size of the read-out at that dose, not a potency): 50%
Compound 4: middle estimate off by 35 percentage points, on the high side, and the stated range ends above it.
By their numbers in this assay, from the lowest: compound 4; then compounds 2, 3 and 1 (each within the scatter of the next, the first and the last beyond it).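

In this assay the aryl group on the amide-type nitrogen proves sensitive to which halogen it carries: chloro in place of fluoro on an aromatic carbon gives a number 32 percentage points lower from compound 2 to compound 4 (beyond the scatter) as a single exchange, whereas fluoro in place of hydrogen, at a number 8 percentage points higher from compound 2 to compound 3 (within the scatter), had not revealed this sensitivity. The wider change to 2-chlorophenyl in place of 2,5-difluorophenyl gives a number 40 percentage points lower from compound 3 to compound 4 (beyond the scatter), so the loss appears from both fluorinated compounds. Nothing available explains the loss.

As far as these compounds go, whether the loss is specific to chloro or extends to other groups in place of fluoro remains open; a bromo, a methyl or a nitrile on that aromatic carbon would distinguish these readings. Also open, from the compounds shown here alone, is how the chloro exchange would read on the core of compound 1.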